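The source may hold more compounds than are shown below. What is called first, only, known or untested is meant among the compounds shown, and "the series" means these compounds.

Working notes on the series. In a functional assay on MCF7 cells (Homo sapiens) for antiproliferative activity, read by MTT assay, with a stated time of 24 h (a higher number here means a weaker inhibitor, a lower number a stronger inhibitor), compound 1 `CCn1c(C(=O)N[C@H](CO)CCCO)ccc1C(CC)(CC)c1ccc(OCS(=O)(=O)c2ccccc2)c(C)c1` gives 31400 nM and compound 2 `CCN(CC)CCNC(=O)c1ccc(C(CC)(CC)c2ccc(OCSC)c(C)c2)n1CC` gives 5160 nM as the lower of the two numbers, with a gap beyond the usual scatter. Compound 2 is therefore the stronger of the two measured compounds, though neither reaches a low potency range on these numbers.

Among the compounds with values here, compound 3 `CCN(CC)CCNC(=O)c1ccc(C(CC)(CC)c2ccc(OCS(C)(=O)=O)c(C)c2)n1CC` keeps the rest of compound 2 and carries methylsulfonyl in place of methylsulfanyl on a saturated chain carbon bound to an oxygen on an aromatic ring in the only structural change.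

Within the data shown here, no measured pair isolates this change, so the expectation is loose. Compound 1 at 31400 nM also holds a sulfonyl group, but it differs from compound 2 in other places too and gives only a weak pointer towards a higher number.

The expected change is a 1.9-fold higher number from compound 2 to compound 3 (0.29 log units; within the scatter) in this assay as a small step towards weaker inhibition, near the edge of the scatter. The estimate for compound 3 is 10000 nM (expected range 3500 nM to 28000 nM).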

Compound 3, half-maximal inhibitory concentration: 14700 nM
For compound 3 the middle estimate is 1.5-fold (0.17 log units) below the measured one; the range from low to high includes it.
By their numbers in this assay, from the lowest: compound 2; then compound 3; then compound 1.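

Within the data shown here, the pair of compound 2 and compound 3 gives the first clean reading of this position in this assay, where methylsulfonyl in place of methylsulfanyl on a saturated chain carbon bound to an oxygen on an aromatic ring gives a 2.8-fold higher number from compound 2 to compound 3 (0.45 log units; beyond the scatter), a modest step towards weaker inhibition with the rest of the structure unchanged. Until now the sulfonyl group appeared only in compound 1, which differs from compound 2 in more than one place, so its contribution could not be separated from the other differences. Nothing available accounts for the direction or size of this step. 

Going by these compounds, the change has been read on a single background, so whether it carries the same sign and size with another amide side chain remains open. It also remains open how a methylsulfinyl group, which would sit between the two sulfur groups shown, or a longer chain such as ethylsulfanyl would read at this position, and whether any such group would give a lower number than the methylsulfanyl of compound 2.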